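Compound 3 to compound 4: methyl for methoxy

This account rests on a few compounds, and the source may have more. Where it says the series, first, only, none or still open, it means among the compounds named here.

In a functional assay on M14 cells (Homo sapiens) for cytotoxicity (on this read-out lower numbers stand for stronger inhibition of growth and higher numbers for weaker inhibition of growth), compound 1 `COc1ccc(C2=C(c3ccc(SC)cc3)CC3CCCN3C2=O)cc1Br` gives 3000 nM and compound 2 `COc1ccc(C2=C(c3ccc(SC)cc3)CC3CCCN3C2=O)cc1OC` gives 5000 nM, while compound 3 `COc1ccc(C2=C(c3ccc(SC)cc3)CC3CCCN3C2=O)cc1` gives 4000 nM within the scatter of both. Compound 4 `CSc1ccc(C2=C(c3ccc(C)cc3)C(=O)N3CCCC3C2)cc1` carries methyl in place of methoxy on an aromatic carbon, para to a large group (methyl in place of methoxy on an aromatic carbon). The measured steps of a 1.7-fold higher number from compound 1 to compound 2 (0.22 log units; within the scatter) and a 1.3-fold higher number from compound 1 to compound 3 (0.12 log units; within the scatter) and a 1.3-fold lower number from compound 2 to compound 3 (0.10 log units; within the scatter) all stay within the scatter and change a different aromatic carbon, so they bear on this swap only indirectly. The estimated step is no change at the digits printed from compound 3 to compound 4 (within the scatter) and no shift beyond the scatter is expected in this assay in either direction. Compound 4 is estimated at 4000 nM (range 1500 nM to 10000 nM).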

Compound 4, concentration for 50% growth inhibition: 6000 nM
Compound 4: the middle estimate sits 1.5-fold (0.18 log units) below what was measured; low and high end bracket the measured number.
By their numbers in this assay, from the lowest: compounds 1, 3, 2 and 4 (each within the scatter of the next).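

Methyl in place of methoxy on the aromatic carbon para to a large group stays within the scatter in this assay: a 1.5-fold higher number from compound 3 to compound 4 (0.18 log units; within the scatter). For the compounds shown here, this is the first direct reading at this position, and the wider swap of 4-methylphenyl in place of 3-bromo-4-methoxyphenyl also stays within the scatter: a 2.0-fold higher number from compound 1 to compound 4 (0.30 log units; within the scatter). Nothing available accounts for either step.

On these data alone, whether an amine or a carboxylic acid on this carbon would shift the number beyond the scatter remains open. So does the effect of a longer chain such as butoxy there.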